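Chloro substitution on pyridyl ethers of two bicyclic cores

This account rests on a few compounds, and the source may have more. Where it says the series, first, only, none or still open, it means among the compounds named here.

Measured in an assay on CHO-K1 cells for displacement of a labelled ligand from Neuronal acetylcholine receptor; alpha4/beta2 (Homo sapiens), read by scintillation counting; a lower number here means a stronger inhibitor, a higher number a weaker inhibitor:
compound 1 `CN1[C@H](COc2cccnc2)C[C@H]2C[C@H]21`: 5.5 nM
compound 2 `C[C@@]12C[C@@H]1CC(COc1cccnc1)N2`: 3.6 nM
compound 3 `CN1[C@H](COc2ccc(Cl)nc2)C[C@H]2C[C@H]21`: 3.4 nM

Compound 3 differs from compound 1 by chloro in place of hydrogen on an aromatic carbon; the step is a 1.6-fold lower number from compound 1 to compound 3 (0.21 log units; within the scatter). Compound 2 has the same atoms as compound 1 joined differently; the difference between the two cores is not broken down here, and the two values lie within the scatter of each other.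

Compound 4 `C[C@@]12C[C@@H]1CC(COc1cncc(Cl)c1)N2` differs from compound 2 by chloro in place of hydrogen on an aromatic carbon. This is the same kind of change as from compound 1 to compound 3, but the place differs: in compound 3 the chloro is next to the ring nitrogen, para to a group of 9 heavy atoms, while in compound 4 it is two atoms from the ring nitrogen, meta to a group of 9 heavy atoms.

In this assay the expected step is a 1.0-fold lower number from compound 2 to compound 4 (0.01 log units; within the scatter), set beside a 1.6-fold lower number from compound 1 to compound 3 (0.21 log units; within the scatter), resting on compound 2 at 3.6 nM and the small shift seen for compound 3; the different place adds uncertainty. Compound 4 is estimated at 3.5 nM, expected between 1.2 nM and 11 nM.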

Compound 4, inhibition constant: 577 nM
For compound 4 the middle estimate is 160-fold (2.22 log units) below the measured one; measured number above the stated range.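

In this assay, chloro in place of hydrogen on an aromatic carbon does not carry over unchanged from one core to the other, giving a 160-fold higher number from compound 2 to compound 4 (2.20 log units; beyond the scatter). The two steps differ: the same change on two cores in this assay, a 1.6-fold lower number (0.21 log units; within the scatter) from compound 1 to compound 3 and a 160-fold higher number (2.20 log units; beyond the scatter) from compound 2 to compound 4, 260-fold (2.41 log units) apart, beyond the scatter of two such steps. This does not show whether the core, the place of the chloro or both account for the gap, as the two steps differ in both at once.

Open, as far as these compounds go, is what chloro does on the core of compound 1 at the place it holds in compound 4, and on the core of compound 2 at the place it holds in compound 3. Also open, from the compounds shown here alone, is whether a methoxy group or a nitrile at the place of the chloro in compound 4 would follow chloro.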